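This account rests on a few compounds, and the source may have more. Where it says the series, first, only, none or still open, it means among the compounds named here.

Measured so far in a functional assay on a cell-free system (plasma, Oryctolagus cuniculus) for inhibition of platelet-activating factor acetylhydrolase (Homo sapiens), tested at 100 nM; on this read-out lower numbers stand for less inhibition and higher numbers for more inhibition at the one concentration tested (going by the name of the read-out):
- compound 1 `CCCCCCCCCCCCN(C)C(=O)Cn1cc(Cc2cnc(O)nc2)c(=O)nc1SCc1ccc(F)cc1` gives 39%
- compound 2 `CCCCCCCCN(C)C(=O)Cn1cc(Cc2cnc(=O)n(CCO)c2)c(=O)nc1SCc1ccc(F)cc1` gives 36%
- compound 3 `CCCCCCCCCCCCN(C)C(=O)Cn1cc(Cc2cnc(=O)n(CC(=O)OCC)c2)c(=O)nc1SCc1ccc(F)cc1` gives 15%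

Compound 3 stands lowest of these three numbers: compound 2 sits higher by more than the usual scatter, and compound 1 higher still, also beyond the scatter. Compound 4 `CCCCCCCCCCCCN(C)C(=O)Cn1cc(Cc2cnc(=O)n(CCO)c2)c(=O)nc1SCc1ccc(F)cc1` has not yet been measured. It differs from compound 3 in a single place: hydroxymethyl in place of ethoxycarbonyl on a saturated chain carbon bound to an aromatic nitrogen. Among the measured compounds shown here, compound 2 carries the same 2-hydroxyethyl group and gives a number close to that of compound 1, but no single step joins it to compound 4, so only its value can be read. For compound 4 an upward step in this assay is expected, likely beyond the scatter, the expected change being a number 15 percentage points higher from compound 3 to compound 4 (beyond the scatter). Compound 4 is therefore estimated at 30%, within a range from 15% to 45%.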

Compound 4, a percentage reported as inhibition, at one concentration (the size of the read-out at that concentration, not a potency): 36%
The estimate for compound 4 lay 6 percentage points below the measured number; measured number inside the range.
By their numbers in this assay, from the lowest: compound 3; then compounds 2, 4 and 1 (each within the scatter of the next).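

In this assay, among the compounds shown here, the swap of ethoxycarbonyl for hydroxymethyl on a saturated chain carbon bound to an aromatic nitrogen gives a number 21 percentage points higher from compound 3 to compound 4 (beyond the scatter) as the first step that can be read directly at this place. With the 2-hydroxyethyl group present, butyl in place of hydrogen on the saturated chain carbon gives no change at the digits printed from compound 2 to compound 4 (within the scatter) and the group of 10 heavy atoms in place of the group of 7 gives a number 3 percentage points lower from compound 1 to compound 4 (within the scatter) so neither change moves the number beyond the scatter.

No further data bear on these steps. Going by these compounds, how an amine or a carboxylic acid in place of hydroxymethyl would read remains open.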